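A few compounds are considered here, and "the series" means these few. Any claim that something is new, unique, unknown or untested is made for them only; others in the source may bear on it.

Compound 1 `COc1ccc(-c2[nH]c3ccc(C(C)C)cc3c2C=O)cc1` gives 97 nM in a functional assay on MCF7 cells (Homo sapiens) for antiproliferative activity, with a stated time of 5 days; on this read-out higher numbers stand for weaker inhibition and lower numbers for stronger inhibition. Compound 2 `COc1ccc(-c2[nH]c3ccc(C(C)(C)C)cc3c2C=O)cc1` differs from it by methyl in place of hydrogen on a saturated chain carbon bound to an aromatic carbon and two saturated chain carbons, and compound 2 gives 580 nM, so the step is a 6.0-fold higher number from compound 1 to compound 2 (0.78 log units; beyond the scatter). Compound 3 `CCCCc1ccc2[nH]c(-c3ccc(C)cc3)c(C=O)c2c1` gives 54 nM in this assay; the difference between the core of compound 1 and the core of compound 3 is not broken down here. Compound 4 `CCCCc1ccc2[nH]c(-c3ccc(CC)cc3)c(C=O)c2c1` differs from compound 3 by methyl in place of hydrogen on a saturated chain carbon bound to an aromatic carbon. This is the same kind of change as that between compound 1 and compound 2, not the same: there the place was a saturated chain carbon bound to an aromatic carbon and two saturated chain carbons, here a saturated chain carbon bound to an aromatic carbon alone. The step to compound 4 is expected to be smaller than the earlier one, a 1.5-fold higher number from compound 3 to compound 4 (0.17 log units; within the scatter), because a 6.0-fold higher number from compound 1 to compound 2 (0.78 log units; beyond the scatter) was measured at a more substituted place. The estimate for compound 4 in this assay is 80 nM, between 40 nM and 200 nM.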

Compound 4, half-maximal inhibitory concentration: 58 nM
Compound 4: the middle estimate sits 1.4-fold (0.14 log units) above what was measured; measured number inside the range.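

Adding one methyl does not give a fixed step in this assay. The new step (a 1.1-fold higher number from compound 3 to compound 4 (0.03 log units; within the scatter)) does not match the earlier one: the same change on two cores in this assay, a 6.0-fold higher number (0.78 log units; beyond the scatter) from compound 1 to compound 2 and a 1.1-fold higher number (0.03 log units; within the scatter) from compound 3 to compound 4, 5.6-fold (0.75 log units) apart, beyond the scatter of two such steps. A step measured on one compound therefore cannot simply be carried over to another in this series, but these two pairs differ both in the carbon that receives the methyl and in the core, so they do not show which of the two accounts for the gap.

As far as these compounds go, it remains open how the two places would compare on one shared core. From the compounds shown here alone, it also remains open what a longer chain, such as propyl, or an amine in place of the added methyl would do.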